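Swapping propyl for phenyl on a sulfur-bearing quinone

The compounds below may be only part of what the source reports. "The series", "measured", "known", "first", "only" and "open" are said of these compounds alone.

Measured compounds:
compound 1 `CC1=CCC[C@H]2[C@](C)(CC3=CC(=O)C=C(Sc4ccccc4)C3=O)[C@@H](C)CC[C@]12C` with 41500 nM
compound 2 `CCCSC1=CC(=O)C(C[C@]2(C)[C@@H](C)CC[C@]3(C)C(C)=CCC[C@@H]23)=CC1=O` with 89500 nM

Two compounds share a common core and a quinone ring carrying a sulfur substituent. In a functional assay on Fem-X cells (Homo sapiens) for cytotoxicity (a higher number here means a weaker inhibitor, a lower number a stronger inhibitor), compound 1 gives 41500 nM, while compound 2 gives 89500 nM. Compound 2 thus has the highest number of the two, standing a little beyond the scatter above compound 1, so it is the weaker of the pair.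

Compound 3 `CC1=CCC[C@H]2[C@](C)(CC3=CC(=O)C(Sc4ccccc4)=CC3=O)[C@@H](C)CC[C@]12C` has not yet been measured. It differs from compound 2 in one place: phenyl in place of propyl on a sulfur. Among the measured compounds shown here, no step between measured compounds covers exactly this change. Still, compound 1 also carries a phenylsulfanyl group and gives 41500 nM, which suggests that a phenylsulfanyl-bearing compound in this series lands in a similar region. A modest drop in the number, near the edge of the scatter, is therefore expected from compound 2 to compound 3, a 2.0-fold lower number from compound 2 to compound 3 (0.30 log units; within the scatter). For compound 3 the estimate is 45000 nM, with a likely range from 20000 nM to 100000 nM.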

Compound 3, half-maximal inhibitory concentration: 42500 nM
Compound 3: middle estimate off by 1.1-fold (0.02 log units), on the high side; measured number inside the range.
By their numbers in this assay, from the lowest: compounds 1 and 3 (each within the scatter of the next); then compound 2.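

On the sulfur of this quinone, phenyl in place of propyl gives a 2.1-fold lower number from compound 2 to compound 3 (0.32 log units; beyond the scatter) in this assay, a modest change that lies beyond the scatter, so the group on the sulfur does affect the reading, though only slightly. The larger aromatic ring brings a small gain, and the number stays high: compound 3 gives 42500 nM, still a weak result, and compound 1, which carries the same phenylsulfanyl group placed differently on the quinone ring, gives 41500 nM, within the scatter of compound 3. Nothing measured here explains the step from propyl to phenyl, so the data record its size but not its cause.

The compounds shown leave open whether a longer chain such as hexyl, a benzyl group, or a phenyl ring bearing a chlorine or a methoxy group on the sulfur would shift the number further. They also leave open how a propylsulfanyl group would read at the placement found in compound 1, and whether an amine or a carboxylic acid on the sulfur-linked chain would change the picture.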